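The source may hold more compounds than are shown below. What is called first, only, known or untested is meant among the compounds shown, and "the series" means these compounds.

Compound 1, `CCc1ccoc1[C@@H](CC)Nc1c(Nc2cccc(C(=O)N(C)C)c2O)c(=O)c1=O`: 379 nM
Compound 2, `CCc1coc([C@@H](CC)Nc2c(Nc3cccc(C(=O)N(C)C)c3O)c(=O)c2=O)c1`: 7 nM
Compound 3, `CCCCc1coc([C@@H](CC)Nc2c(Nc3cccc(C(=O)N(C)C)c3O)c(=O)c2=O)c1`: 34 nM

These numbers come from an assay on CHO cells for displacement of a labelled ligand from C-X-C chemokine receptor type 1 (Homo sapiens); on this read-out higher numbers stand for weaker inhibition and lower numbers for stronger inhibition. Compound 3 stands second highest of the three; compound 2 gives a lower number and compound 1 a higher one. Compound 4, `CCC(CC)c1coc([C@@H](CC)Nc2c(Nc3cccc(C(=O)N(C)C)c3O)c(=O)c2=O)c1`, differs from compound 3 in one place: pentan-3-yl in place of butyl on an aromatic carbon. The step that bears most directly on this is a 4.9-fold higher number from compound 2 to compound 3 (0.69 log units; beyond the scatter), where a longer chain on the same furan carbon brought a modest weakening. The other two steps, a 54-fold lower number from compound 1 to compound 2 (1.73 log units; beyond the scatter) and an 11-fold lower number from compound 1 to compound 3 (1.05 log units; beyond the scatter), swap 3-ethylfuran-2-yl for 4-ethylfuran-2-yl or 4-butylfuran-2-yl and are large, but concern a different change. For compound 4 the expected step is a 1.2-fold higher number from compound 3 to compound 4 (0.07 log units; within the scatter), small and uncertain in direction. Compound 4 is estimated at 40 nM in this assay, with a range from 12 nM to 130 nM.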

Compound 4, inhibition constant: 30 nM
Estimate against measurement, compound 4: 1.3-fold (0.12 log units) above; measured number inside the range.
By their numbers in this assay, from the lowest: compound 2; then compounds 4 and 3 (each within the scatter of the next); then compound 1.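

At this furan carbon, the butyl chain of compound 3 and the pentan-3-yl group of compound 4 cannot be told apart (a 1.1-fold lower number from compound 3 to compound 4 (0.05 log units; within the scatter)), so rearranging the chain into this branched form changes nothing measurable. Ethyl still gives the better result (a 4.3-fold higher number from compound 2 to compound 4 (0.63 log units; beyond the scatter)). Even so, the larger group keeps most of the advantage over the 3-ethylfuran-2-yl arrangement (a 13-fold lower number from compound 1 to compound 4 (1.10 log units; beyond the scatter)).

Nothing shown gives a reason for these steps. From the compounds shown here alone, whether methyl, a cyclopentyl ring or an amine at this carbon would match ethyl remains open.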